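Cytotoxicity notes on a benzyloxy-for-bromo exchange

The source may report more compounds than this note shows. Statements on the series, on what has been measured and on what is new or still open speak of the compounds shown alone.

Three compounds of the series have been run in an ADME assay on HEK293 cells (Homo sapiens) for cytotoxicity, read by MTT assay, with a stated time of 24 h; a lower number here means a stronger inhibitor, a higher number a weaker inhibitor. Compound 1 `Cc1cc(O)c(C(=O)/C=C/c2ccc(F)cc2)c(-c2ccc(OCc3ccccc3)cc2)c1C(=O)/C=C/c1ccc(F)cc1` gives 30000 nM in this assay. Compound 2 `Cc1cc(O)c(C(=O)/C=C/c2ccc(OCc3ccccc3)cc2)c(-c2ccc(Br)cc2)c1C(=O)/C=C/c1ccc(OCc2ccccc2)cc1` gives 25000 nM in this assay. Compound 3 `Cc1cc(O)c(C(=O)/C=C/c2ccc(F)cc2)c(-c2ccc(Br)cc2)c1C(=O)/C=C/c1ccc(F)cc1` gives 20000 nM in this assay. The three numbers sit within the usual scatter of one another, so no order among them is claimed.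

One change is seen twice. From compound 3 to compound 1 the change is benzyloxy in place of bromo on an aromatic carbon, and it made a step of a 1.5-fold higher number from compound 3 to compound 1 (0.18 log units; within the scatter). From compound 2 to compound 4 `Cc1cc(O)c(C(=O)/C=C/c2ccc(OCc3ccccc3)cc2)c(-c2ccc(OCc3ccccc3)cc2)c1C(=O)/C=C/c1ccc(OCc2ccccc2)cc1`, not yet measured, the change is benzyloxy in place of bromo on an aromatic carbon; the place reads the same word for word, so it is the same change. How the core of compound 2 differs from the core of compound 3 is not broken down here.

For compound 4 the expected step is a 1.3-fold higher number from compound 2 to compound 4 (0.11 log units; within the scatter), resting on the same change having produced a 1.5-fold higher number from compound 3 to compound 1 (0.18 log units; within the scatter), a step within the scatter. Compound 4 is estimated at 32000 nM in this assay, with a range expected from 15000 nM to 65000 nM.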

Compound 4, half-maximal inhibitory concentration: 30000 nM
Compound 4: the middle estimate sits 1.1-fold (0.03 log units) above what was measured; the range from low to high includes it.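

Benzyloxy in place of bromo gives a 1.2-fold higher number from compound 2 to compound 4 (0.08 log units; within the scatter) in this assay, so on this core, as on the first, the step stays within the scatter. The two readings of the change can be set side by side, and they do not differ: the same change on two cores in this assay, a 1.5-fold higher number (0.18 log units; within the scatter) from compound 3 to compound 1 and a 1.2-fold higher number (0.08 log units; within the scatter) from compound 2 to compound 4, 1.3-fold (0.10 log units) apart, within the scatter of two such steps. This shows that on these two cores the exchange carries across without a detectable difference, but only in the sense that neither step rises beyond the scatter; it does not show that the change has a real effect of its own, nor that a step of the same size would appear on a core outside this set.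

At this place, on an aromatic carbon para to a large group, the compounds shown carry only bromo or benzyloxy, so the outcome with an amine, a carboxylic acid or a longer chain there remains open. Also open, from the compounds shown here alone, is whether the exchange would still give no step beyond the scatter in any other assay.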